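A Dimethoxyphenyl Swap at the Carbonyl of Compound 1

The source may hold more compounds than are shown below. What is called first, only, known or untested is meant among the compounds shown, and "the series" means these compounds.

Compound 1 `COc1cc(-c2cc(/C=C/C(=O)c3ccc(Cl)c(Cl)c3)[nH]n2)cc(OC)c1OC` was tested in a functional assay on MDA-MB-435 cells (Homo sapiens) for inhibition, read by sulforhodamine B assay, with a stated time of 48 h; a higher number here means that more compound is tolerated, a lower number that less compound is tolerated. In this assay compound 1 reaches only a limit of the assay and not a number, > 100000 nM, as shown by the limit of > 100000 nM in this assay, at which 1 of the 2 values shown sits. Compound 2 `COc1ccc(-c2cc(/C=C/C(=O)c3ccc(N)cc3)[nH]n2)cc1OC` differs from it in more than one place and gives 40800 nM in this assay. Compound 3 `COc1ccc(C(=O)/C=C/c2cc(-c3cc(OC)c(OC)c(OC)c3)n[nH]2)cc1OC` carries 3,4-dimethoxyphenyl in place of 3,4-dichlorophenyl on a carbonyl carbon. Among the compounds with values here, no measured step anchors this change. The expected step of an at least 1.4-fold lower number from compound 1 to compound 3 (0.15 log units; that floor lies within the scatter) in this assay is therefore small, within the usual scatter. Compound 3 is estimated at 70000 nM, between 15000 nM and 250000 nM.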

Compound 3, concentration lethal to 50% of the cells: 5520 nM
For compound 3 the middle estimate is 13-fold (1.10 log units) above the measured one; measured number below the stated range.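

The group on this carbonyl carbon clearly matters in this assay, as replacing 3,4-dichlorophenyl with 3,4-dimethoxyphenyl gives an at least 18-fold lower number from compound 1 to compound 3 (1.25 log units; beyond the scatter). This is the only measured step at this place among the compounds shown, and it replaces a limit of the assay with a number for compound 3 . Its size is a floor and not an exact figure, because one end of the step is a limit: the limit of > 100000 nM in this assay, at which 1 of the 3 values shown sits.

On these data alone, how a phenyl ring bearing a carboxylic acid or a nitrile would behave on this carbonyl carbon remains open. So does whether the same step would hold on a core other than that of compound 1 .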